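The source may hold more compounds than are shown below. What is called first, only, known or untested is meant among the compounds shown, and "the series" means these compounds.

Of the compounds shown here, two of a shared core have so far been tested in a functional assay on A549 cells (Homo sapiens) for inhibition, read by MTT assay, with a stated time of 24 h, tested at 10 uM; a lower number here means less inhibition of growth, a higher number more inhibition of growth at the concentration tested. Compound 1, `N#Cc1ccc(-c2cnc3[nH]cc(-c4nnc(-c5ccc(Cl)cc5)o4)c(=O)c3c2)cc1`, gives 12.5% in this assay. Among the measured compounds shown here, compound 2, `Cc1ccc(-c2nnc(-c3c[nH]c4ncc(-c5ccc(S(C)(=O)=O)cc5)cc4c3=O)o2)cc1`, gives 11.2% in this assay; the only other number, that of compound 1, lies within the usual scatter of it, so the two compounds cannot be told apart on this read-out, and both show little inhibition of growth at the concentration tested.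

Compound 3, `Cc1cccc(-c2nnc(-c3c[nH]c4ncc(-c5ccc(S(C)(=O)=O)cc5)cc4c3=O)o2)c1`, has not yet been measured. It differs from compound 2 in one place: 3-methylphenyl in place of 4-methylphenyl on an aromatic carbon. For the measured compounds named here, no pair of measured compounds that differ in a single place is available, so no step of this kind has been observed, and nothing among the measured compounds points to a move in either direction. The account therefore expects the step from compound 2 to compound 3 to stay within the scatter, as a number 0.8 percentage points higher from compound 2 to compound 3 (within the scatter) expresses. Compound 3 is accordingly estimated to give 12% in this assay, with a range from 3% to 22%.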

Compound 3, percent growth inhibition at one concentration: 8.95%
For compound 3 the middle estimate is 3.1 percentage points above the measured one; the measured number falls inside the stated range.
By their numbers in this assay, from the lowest: compounds 3, 2 and 1 (each within the scatter of the next).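

In this assay, among the compounds shown here, putting 3-methylphenyl in place of 4-methylphenyl on an aromatic carbon of the five-membered aromatic ring with 2 nitrogen and 1 oxygen gives a number 2.3 percentage points lower from compound 2 to compound 3 (within the scatter), the first step available between compounds that differ in one place. On this read-out, compound 2 and compound 3 therefore cannot be told apart, so this exchange of one methylphenyl group for the other gives no sign of an effect on inhibition of growth at the concentration tested. No independent measurement is available that bears on this result.

From the compounds shown here alone, both groups seen at this position are phenyl rings carrying a single methyl, so it remains open whether an amine, a carboxylic acid or a longer chain such as butyl on that phenyl ring would give a step beyond the scatter. Going by these compounds, it also remains open whether the exchange of 4-methylphenyl for 3-methylphenyl would read the same way on a compound in which the methylsulfonyl group of compound 2 and compound 3 gives way to a carboxylic acid.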